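Chain length and the step to compound 3

The source may report more compounds than this note shows. Statements on the series, on what has been measured and on what is new or still open speak of the compounds shown alone.

Compound 1 `COc1cc2c(Nc3ccc(F)c(Cl)c3)ncnc2cc1OCCCn1ccnc1[N+](=O)[O-]`: 6140 nM
Compound 2 `COc1cc2c(Nc3ccc(F)c(Cl)c3)ncnc2cc1OCCCCCCn1ccnc1[N+](=O)[O-]`: 5630 nM

Both values come from a functional assay on HT-29 cells (Homo sapiens) for inhibition, read by sulforhodamine B assay, with a stated time of 72 h; a lower number here means a stronger inhibitor, a higher number a weaker inhibitor. Within the data shown here, compound 1 stands level with the only other measured compound, with a 1.1-fold lower number from compound 1 to compound 2 (0.04 log units; within the scatter).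

Compound 3 `COc1cc2c(Nc3ccc(F)c(Cl)c3)ncnc2cc1OCCOCCn1ccnc1[N+](=O)[O-]` keeps the shared core and alters the chain: 2-(2-nitro-1H-imidazol-1-yl)ethoxy in place of (2-nitro-1H-imidazol-1-yl)methyl on a saturated chain carbon, two bonds along the chain from an oxygen on an aromatic ring. Put simply, 2-(2-nitro-1H-imidazol-1-yl)ethoxy stands in place of (2-nitro-1H-imidazol-1-yl)methyl on a saturated chain carbon, two bonds along the chain from an oxygen on an aromatic ring.

Among the measured compounds shown here, only one measured step bears on this change. It also extends the chain, with 3-(2-nitro-1H-imidazol-1-yl)propyl in place of 2-nitro-1H-imidazol-1-yl, and it gave a 1.1-fold lower number from compound 1 to compound 2 (0.04 log units; within the scatter). For the measured compounds named here, no measured compound carries the new ethoxy group, so this single step is thin evidence and the range must stay wide. No step beyond the scatter is therefore expected in this assay. The expected step is a 1.0-fold lower number from compound 1 to compound 3 (0.01 log units; within the scatter). For compound 3 the estimated value is 6000 nM, with an expected range from 2800 nM to 13000 nM.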

Compound 3, half-maximal inhibitory concentration: 9860 nM
Estimate against measurement, compound 3: 1.6-fold (0.22 log units) below; the measured number falls inside the stated range.
By their numbers in this assay, from the lowest: compounds 2, 1 and 3 (each within the scatter of the next).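

Swapping the (2-nitro-1H-imidazol-1-yl)methyl group for 2-(2-nitro-1H-imidazol-1-yl)ethoxy, with 5 hydrogen-bond acceptors in place of 4, leaves the reading in this assay within the scatter (a 1.6-fold higher number from compound 1 to compound 3 (0.21 log units; within the scatter)). Compared with the longer all-carbon chain, the result is the same (a 1.8-fold higher number from compound 2 to compound 3 (0.24 log units; within the scatter)), so this position now accepts a chain containing the ethoxy link as well as the two chains of different length seen before, with no step beyond the scatter among the three compounds. No supporting measurement is available to explain why these numbers stay so close.

As far as these compounds go, all three compounds end in the same 2-nitro-1H-imidazol-1-yl group, so it remains open whether a chain ending in an amine or a carboxylic acid would give a step beyond the scatter. From the compounds shown here alone, it also remains open whether a much longer chain, or one with further ethoxy units, would keep the numbers this close.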